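From phenyl to 2-chlorophenyl on compound 1

This account rests on a few compounds, and the source may have more. Where it says the series, first, only, none or still open, it means among the compounds named here.

Compound 1 (`CCOC(=O)[C@@]1(C(=O)Nc2ccccc2)C[C@@H]1c1cc(OC)c(OC)c(OC)c1`) offers only a lower bound as a starting point. In a functional assay on A549 cells (Homo sapiens) for cytotoxicity, read by MTT assay, with a stated time of 48 h (a lower number here means a stronger inhibitor, a higher number a weaker inhibitor), compound 1 gives > 100000 nM and this is a limit of the assay, not a number. Compound 3 (`CCOC(=O)[C@@]1(C(=O)Nc2ccccc2Cl)C[C@@H]1c1cc(OC)c(OC)c(OC)c1`) keeps the core of compound 1 and differs in one place: chloro in place of hydrogen on an aromatic carbon with chloro in place of hydrogen on an aromatic carbon, ortho to a large group. Compound 2 (`CCOC(=O)C1(C(=O)Nc2ccccc2Cl)CC1c1cc(OC)c(OC)c(OC)c1`) also carries the (2-chlorophenyl)carbamoyl group, and in this assay compound 2 gives 18000 nM; 18500 nM (2 entries) across two closely agreeing entries (the several entries of compound 2 in this assay, 18000 nM; 18500 nM (2 entries)). Among the measured compounds shown here, no measured step connects these compounds, so that value is the only guide here. The expected change is an at least 6.2-fold lower number from compound 1 to compound 3 (0.79 log units; beyond the scatter) and it points toward stronger inhibition. Compound 3 is expected at about 16000 nM (estimated range 6000 nM to 50000 nM).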

Compound 3, half-maximal inhibitory concentration: 29000 nM
Beside the measured number, compound 3's estimate is 1.8-fold (0.26 log units) below it; the measured number falls inside the stated range.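

Compound 3 turns the estimate into a direct comparison: in this assay, chloro in place of hydrogen on an aromatic carbon, ortho to a large group, gives an at least 3.4-fold lower number from compound 1 to compound 3 (0.53 log units; beyond the scatter). As far as these compounds go, the value of compound 1 is a limit of the assay and not a number, so this step gives only the smallest possible size of the change, and the true size stays unknown: the limit of > 100000 nM in this assay, at which 1 of the 3 values shown sits. The step also links two compounds drawn with a defined configuration, which compound 2 could not do: the fact that one of compounds 2 and 3 is drawn with a defined configuration and the other without, at the place where they differ.

From the compounds shown here alone, whether a fluoro or a methyl group on the same aromatic carbon would give a similar step remains open. Also open, going by these compounds, is whether chloro would have the same effect on a different carbon of this ring.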